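From 4-fluorophenyl to 3-fluorophenyl on the amide

A few compounds are considered here, and "the series" means these few. Any claim that something is new, unique, unknown or untested is made for them only; others in the source may bear on it.

Measured in a functional assay on BaF3 cells (Mus musculus) for antiproliferative activity, read by CCK-8 assay and cell counting, with a stated time of 76 h; on this read-out higher numbers stand for weaker inhibition and lower numbers for stronger inhibition:
- compound 1 `COc1cc2nccc(Oc3ccc(Nc4nn(C)cc4C(=O)Nc4ccccc4)cc3)c2cc1C(N)=O`: > 10000 nM
- compound 2 `COc1cc2nccc(Oc3ccc(Nc4nn(C)cc4C(=O)Nc4ccc(F)cc4)cc3)c2cc1C(N)=O`: 3060 nM

Compound 1 gives > 10000 nM, which is a limit of the assay and not a number. Among the compounds with values here, that leaves compound 2, at 3060 nM, as the only true number so far. Compound 3 `COc1cc2nccc(Oc3ccc(Nc4nn(C)cc4C(=O)Nc4cccc(F)c4)cc3)c2cc1C(N)=O` keeps the same atoms but moves the fluorine: 3-fluorophenyl in place of 4-fluorophenyl on an amide-type nitrogen, with 3-fluorophenyl in place of 4-fluorophenyl on an amide-type nitrogen. Within the data shown here, the one measured step that bears on this is the addition of fluorine, an at least 3.2-fold lower number from compound 1 to compound 2 (0.51 log units; beyond the scatter). Among the measured compounds shown here, it shows that fluorine can matter here, but no measured compound has it in the new place, so no clear direction is expected in this assay. The expected step is a 1.3-fold higher number from compound 2 to compound 3 (0.12 log units; within the scatter), not beyond the scatter. For compound 3 the estimate is 4000 nM, with an expected range of 1500 nM to 10000 nM.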

Compound 3, half-maximal inhibitory concentration: 4480 nM
Estimate against measurement, compound 3: 1.1-fold (0.05 log units) below; the range from low to high includes it.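

In this assay, moving the fluorine from 4-fluorophenyl to 3-fluorophenyl on the amide-type nitrogen gives a 1.5-fold higher number from compound 2 to compound 3 (0.17 log units; within the scatter), so this assay does not separate the two placements. Fluorine in the new place also gives an at least 2.2-fold lower number from compound 1 to compound 3 (0.34 log units; beyond the scatter), so the lower number is not tied to a single place on the ring. The size of that step is only a bound because compound 1 stands at a limit of the assay: the limit of > 10000 nM in this assay, at which 1 of the 3 values shown sits.

From the compounds shown here alone, whether chlorine, a methoxy group or an amine on that ring would bring the number lower remains open.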